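Replacing the 3-hydroxyphenyl group of compound 2

The source may report more compounds than this note shows. Statements on the series, on what has been measured and on what is new or still open speak of the compounds shown alone.

Among the compounds with values here, in a functional assay on MCF7 cells (Homo sapiens) for antiproliferative activity, read by MTT assay, with stated times of 24 h and 72 h (a lower number here means a stronger inhibitor, a higher number a weaker inhibitor), compound 2 `COc1cc(N2C(=O)[C@@H](Oc3ccccc3)[C@H]2c2cccc(O)c2)cc(OC)c1OC` gives 54000 nM, the higher of the two numbers so far, while compound 1 `COc1cc(N2C(=O)[C@@H](Oc3ccccc3)[C@H]2c2ccc([S+](C)[O-])cc2)cc(OC)c1OC` gives 20000 nM. Compound 3 `COc1cc([N+](=O)[O-])c([C@@H]2[C@H](Oc3ccccc3)C(=O)N2c2cc(OC)c(OC)c(OC)c2)cc1O` replaces the 3-hydroxyphenyl group on a saturated ring carbon of the four-membered ring: a group of 12 heavy atoms (7 carbon, 1 nitrogen, 4 oxygen; one six-membered aromatic ring of carbon only) in place of a group of 7 heavy atoms (6 carbon, 1 oxygen; one six-membered aromatic ring of carbon only), on a saturated ring carbon. Within the data shown here, only one measured step changes this same place, a 2.7-fold higher number from compound 1 to compound 2 (0.43 log units; beyond the scatter), and it is modest. With the larger group of compound 1 on the lower side of that step, a modest move to a lower number is expected, though this is a single, uncertain guide. The expected step is a 3.6-fold lower number from compound 2 to compound 3 (0.56 log units; beyond the scatter) in this assay. For compound 3, the estimated value is 15000 nM, within an expected range of 1500 nM to 60000 nM.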

Compound 3, half-maximal inhibitory concentration: 59000 nM
The estimate for compound 3 lay 3.9-fold (0.59 log units) below the measured number; the measured number falls inside the stated range.
By their numbers in this assay, from the lowest: compound 1; then compounds 2 and 3 (each within the scatter of the next).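

In this assay, the step is a 1.1-fold higher number from compound 2 to compound 3 (0.04 log units; within the scatter), so the larger group of compound 3 and the 3-hydroxyphenyl group read as level at this saturated ring carbon. The other new step is a 3.0-fold higher number from compound 1 to compound 3 (0.47 log units; beyond the scatter), which shows that group size alone does not set the number here, since compound 3 carries the largest of the three groups while compound 1 keeps the lowest number. No measurement at hand explains this result.

Still open, as far as these compounds go, is how a simple amine or a carboxylic acid on the aromatic ring would read at this position. From the compounds shown here alone, whether any group here can bring the number below that of compound 1 also remains unknown.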